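The source may report more compounds than this note shows. Statements on the series, on what has been measured and on what is new or still open speak of the compounds shown alone.

Measured compounds in a functional assay on MCF7 cells (Homo sapiens) for antiproliferative activity, read by MTT assay, with a stated time of 24 h, tested at 10 uM; a higher number here means more inhibition at the concentration tested (going by the name of the read-out), a lower number less inhibition:
compound 1 `O=C(NS(=O)(=O)c1ccc(Cl)cc1)n1ccc2cccnc21` — 33.5%
compound 2 `O=C(NS(=O)(=O)c1cccc([N+](=O)[O-])c1)n1ccc2cccnc21` — 70.7%
compound 3 `Cc1ccc(S(=O)(=O)NC(=O)n2ccc3cccnc32)cc1` — 20.3%

Compound 2 stands highest of the three numbers in this assay; compound 1 lies beyond the scatter below it, and compound 3 further still. Among the compounds with values here, the only single-change step measured, a number 13.2 percentage points lower from compound 1 to compound 3 (beyond the scatter), concerns a substituent on the aryl sulfonyl ring, not the shared core. Compound 4 `O=C(NS(=O)(=O)c1cccc([N+](=O)[O-])c1)n1ccc2cc(Br)cnc21` differs from compound 2 by bromo in place of hydrogen on an aromatic carbon. Within the data shown here, no measured step bears on a change at the core, so the only guide is the unchanged remainder of compound 2 with its 70.7%. The step expected is a number 2.7 percentage points lower from compound 2 to compound 4 (within the scatter), nothing beyond the scatter in either direction. Compound 4 is estimated at 68%, within a range of 45% to 85%.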

Compound 4, a percentage reported as inhibition, at one concentration (the size of the read-out at that concentration, not a potency): 43.1%
For compound 4 the middle estimate is 24.9 percentage points above the measured one; the measured number lies below the stated range.
By their numbers in this assay, from the lowest: compound 3; then compounds 1 and 4 (each within the scatter of the next); then compound 2.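

In this assay, the step of a number 27.6 percentage points lower from compound 2 to compound 4 (beyond the scatter) with bromo in place of hydrogen shows that the shared core is not indifferent to substitution. A single bromo on an aromatic carbon of the six-membered aromatic ring with 1 nitrogen, two atoms from the ring nitrogen, moves the number beyond the scatter, whereas the earlier step concerned only the aryl sulfonyl ring. No available evidence bears on the reason for this drop.

On these data alone, whether an amine or a methyl at this position gives a similar step remains open. So does whether bromo has the same effect alongside the chloro or methyl aryl sulfonyl groups.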